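This account rests on a few compounds, and the source may have more. Where it says the series, first, only, none or still open, it means among the compounds named here.

Of the compounds shown here, three sharing one long saturated chain have been tested in an ADME assay on cells (Splenocyte, Mus musculus, strain BALB/c) for cytotoxicity, read by MTT assay, tested at 10 ug/mL; on this read-out lower numbers stand for a weaker effect and higher numbers for a stronger effect at the one concentration tested. Compound 1 `CCCCCCCCCCCCCCC(NC(=O)OC(C)(C)C)C(=O)O` gives 5.1% in this assay. Compound 2 `CCCCCCCCCCCCCCC(CN)NC(=O)OC(C)(C)C` gives 4.3%, and compound 3 `CCCCCCCCCCCCCCC(CN(CC)CC)NC(=O)OC(C)(C)C` gives 7.8%. Among these three numbers compound 1 stands second highest, yet every gap is small: the step of a number 0.8 percentage points lower from compound 1 to compound 2 (within the scatter), the step of a number 2.7 percentage points higher from compound 1 to compound 3 (within the scatter) and the step of a number 3.5 percentage points higher from compound 2 to compound 3 (within the scatter) all lie within the scatter, so the three compounds cannot be told apart on this read-out.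

The next compound, compound 4 `CCCCCCCCCCCCCCC(C(=O)O)N(CC)CC`, differs from compound 1 in one place: diethylamino in place of (tert-butoxycarbonyl)amino on a saturated chain carbon bound to a carbonyl carbon and a saturated chain carbon. Among the compounds with values here, two measured steps touch the entering group. The step of a number 3.5 percentage points higher from compound 2 to compound 3 (within the scatter) put diethylamino in the place of amino, and the step of a number 2.7 percentage points higher from compound 1 to compound 3 (within the scatter) put (diethylamino)methyl in the place of carboxy; neither moved the number beyond the scatter. No measured step removes the (tert-butoxycarbonyl)amino group, so that side of the change has no precedent among these compounds. Since the entering group has shown no effect beyond the scatter, no step beyond the scatter is expected in this assay, namely a number 1.9 percentage points higher from compound 1 to compound 4 (within the scatter). Compound 4 is therefore estimated at 7%, with a range from 0% to 20%.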

Compound 4, a percentage reported as activity, at one concentration (the size of the read-out at that concentration, not a potency): 12.1%
Estimate against measurement, compound 4: 5.1 percentage points below, and the stated range covers the measured number.
By their numbers in this assay, from the lowest: compounds 2, 1, 3 and 4 (each within the scatter of the next).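

Within the data shown here, compound 4 gives the first look at losing the (tert-butoxycarbonyl)amino group, and the swap to diethylamino on a saturated chain carbon bound to a carbonyl carbon and a saturated chain carbon is a large one in atom count: 8 heavy atoms leave, 5 enter, and the hydrogen-bond donor of the leaving group has no counterpart in the entering one. Even so, in this assay the result is a number 7 percentage points higher from compound 1 to compound 4 (within the scatter), so with the carboxy group kept, this exchange at this position does not separate the two compounds, and the (tert-butoxycarbonyl)amino group is shown not to be needed to keep the number at this level. Nothing measured alongside these numbers speaks to why the read-out behaves this way.

Open, on these data alone, is whether a smaller dimethylamino group or a ring amine such as piperidine on this same carbon, with the carboxy group kept, would also stay within the scatter. Also open, as far as these compounds go, is whether a shorter chain in place of the long saturated one would move the number in this assay further than any change at this carbon has done so far.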